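A few compounds are considered here, and "the series" means these few. Any claim that something is new, unique, unknown or untested is made for them only; others in the source may bear on it.

In a functional assay on NALM-6 cells (Homo sapiens) for cytotoxicity, with a stated time of 72 h (a higher number here means that more compound is needed for the effect, a lower number that less compound is needed), compound 2 `C=C[C@@](C)(/C=C/c1ccc(O)cc1)CC/C=C/C#N` gives > 43400 nM, which is a limit and not a number. Compound 1 `C=C[C@@](C)(/C=C/c1ccc(O)cc1)CCC1OC1(C)C` gives > 43400 nM, which is also a limit. Among the measured compounds shown here, the only measured step is a step that the two limits leave unreadable from compound 1 to compound 2, so it offers no size to carry forward.

Compound 3 `C=C[C@@](C)(/C=C/c1ccc(O)cc1)CC/C=C(\C)C=O` differs from compound 2 in one place: 2-formylprop-1-en-1-yl in place of 2-cyanoethenyl on a saturated chain carbon, three bonds along the chain from two double-bonded chain carbons. In words, 2-formylprop-1-en-1-yl stands in place of 2-cyanoethenyl on a saturated chain carbon, three bonds along the chain from two double-bonded chain carbons.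

Because of the limit of > 43400 nM in this assay, at which 2 of the 2 values shown sit, no measured number anchors the expectation, and another limit is the likeliest result. A small move toward less compound needed in this assay is possible, but no large step is expected. The expected step is an at least 1.0-fold lower number from compound 2 to compound 3 (0.03 log units; that floor lies within the scatter). Compound 3 is estimated at 40000 nM, with an expected range from 12000 nM to 60000 nM.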

Compound 3, half-maximal effective concentration: 12600 nM
For compound 3 the middle estimate is 3.2-fold (0.50 log units) above the measured one; measured number inside the range.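

Until now this chain end had given no number in this assay, only a limit: the limit of > 43400 nM in this assay, at which 2 of the 3 values shown sit.

Compound 3, with 2-formylprop-1-en-1-yl at this place, gives the first measured number, and the comparisons show an at least 3.4-fold lower number from compound 2 to compound 3 (0.53 log units; beyond the scatter) and an at least 3.4-fold lower number from compound 1 to compound 3 (0.53 log units; beyond the scatter). The group on this chain carbon can therefore change the read-out, though each step is only a floor, so the true size may be larger.

The compounds shown cannot tell which part of the entering group, the formyl or its methyl, carries the step. On these data alone, a carboxylic acid or a hydroxymethyl group in place of the formyl, or the same chain without the methyl, would help to separate these parts, and how such groups read here remains open.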